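Thiophen-2-yl for phenyl: expected cytotoxicity of compound 3

This account rests on a few compounds, and the source may have more. Where it says the series, first, only, none or still open, it means among the compounds named here.

Compound 1 `COc1nc(C)nc(/N=C(\C)c2ccccc2)n1` is the reference point of this account. In an ADME assay on Vero cells (Chlorocebus sabaeus) for cytotoxicity, read by MTT assay, with a stated time of 72 h (a higher number here means a weaker inhibitor, a lower number a stronger inhibitor), compound 1 gives "not determined" (no result reported), so no single number places it on the scale. Among the compounds with values here, the one other value shown sits at a limit of the assay, (the limit of > 50 ug/mL in this assay, at which 1 of the 2 values shown sits). That value belongs to compound 2 `COc1nc(C)nc(/N=C(\C)c2ccc(O)cc2)n1`. In this assay compound 2 gives > 50 ug/mL, which is a limit of the assay and not a number. Compound 3 `COc1nc(C)nc(/N=C(\C)c2cccs2)n1` is not yet measured. It differs from compound 1 in one place: thiophen-2-yl in place of phenyl on a carbon with a double bond to nitrogen. Within the data shown here, no measured step between two compounds of this set is available, so the size of the change cannot be read from a precedent. Among the measured compounds shown here, the writer expects no step in this assay beyond the usual scatter for compound 3, in either direction. Compound 3 is therefore estimated at 60 ug/mL, within a range from 25 ug/mL to 150 ug/mL, and most likely reported again only as a limit.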

Compound 3, half-maximal inhibitory concentration: > 50 ug/mL
Compound 3 was reported as a limit (the forecaster's own chance of this, stated with the estimate: 70%); the middle value is on the limit's open side.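

In this assay compound 3 gives > 50 ug/mL, which is a limit of the assay and not a number. Within the data shown here, compound 1 gives "not determined" (no result reported), so no step between compound 1 and compound 3 can be read. The compounds shown leave open whether thiophen-2-yl in place of phenyl changes the read-out at all.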